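Side-group swap: compound 3 to compound 4

A few compounds are considered here, and "the series" means these few. Any claim that something is new, unique, unknown or untested is made for them only; others in the source may bear on it.

Of the compounds shown here, three sharing one core have been read in a functional assay on HUVEC cells (Homo sapiens), read by scintillation counting and thymidine incorporation, with a stated time of 24 h; on this read-out higher numbers stand for weaker inhibition and lower numbers for stronger inhibition. Compound 1 (`CCC(C)n1ncn(-c2ccc(N3CCN(c4ccc(OC[C@@H]5CO[C@@](Cn6cnc(C(F)(F)F)n6)(c6ccc(Cl)cc6Cl)O5)cc4)CC3)cc2)c1=O`) gives 270 nM, compound 2 (`CCC(C)n1ncn(-c2ccc(N3CCN(c4ccc(OC[C@@H]5CO[C@@](Cn6ccnc6-c6ccccc6)(c6ccc(Cl)cc6Cl)O5)cc4)CC3)cc2)c1=O`) gives 136 nM, and compound 3 (`CCC(C)n1ncn(-c2ccc(N3CCN(c4ccc(OC[C@@H]5CO[C@@](Cn6c(C)cnc6C)(c6ccc(Cl)cc6Cl)O5)cc4)CC3)cc2)c1=O`) gives 765 nM. Compound 3 therefore has the highest number of the three and is the weakest inhibitor so far.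

Compound 4 (`CCC(C)n1ncn(-c2ccc(N3CCN(c4ccc(OC[C@@H]5CO[C@@](Cn6cc(C(F)(F)F)nc6C)(c6ccc(Cl)cc6Cl)O5)cc4)CC3)cc2)c1=O`) is not yet measured. It has 2-methyl-4-(trifluoromethyl)-1H-imidazol-1-yl in place of 2,5-dimethyl-1H-imidazol-1-yl on a saturated chain carbon bound to a saturated ring carbon.

All three measured steps sit at this same place. The swap in a 2.0-fold lower number from compound 1 to compound 2 (0.30 log units; within the scatter) stays within the scatter, while a 2.8-fold higher number from compound 1 to compound 3 (0.45 log units; beyond the scatter) and a 5.6-fold higher number from compound 2 to compound 3 (0.75 log units; beyond the scatter) are modest. Among the measured compounds shown here, the closest guide is a 2.8-fold higher number from compound 1 to compound 3 (0.45 log units; beyond the scatter), since compound 1 is the only measured compound with a trifluoromethyl group, though on a different ring. For the measured compounds named here, no measured step isolates that group on an imidazolyl ring, and three compounds support no rule.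

A modest step toward stronger inhibition in this assay is nevertheless expected: a 2.3-fold lower number from compound 3 to compound 4 (0.35 log units; beyond the scatter). For compound 4 the estimated value is 340 nM, with an expected range of 140 nM to 800 nM.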

Compound 4, half-maximal inhibitory concentration: 441 nM
Compound 4: middle estimate off by 1.3-fold (0.11 log units), on the low side; the range from low to high includes it.
By their numbers in this assay, from the lowest: compounds 2, 1, 4 and 3 (each within the scatter of the next, the first and the last beyond it).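

In this assay, among the compounds shown here, a trifluoromethyl group on an imidazolyl ring can now be read for the first time at this place, on a saturated chain carbon bound to a saturated ring carbon: a 1.7-fold lower number from compound 3 to compound 4 (0.24 log units; within the scatter), so 2-methyl-4-(trifluoromethyl)-1H-imidazol-1-yl and 2,5-dimethyl-1H-imidazol-1-yl are not separated here. The same holds across ring types that both carry trifluoromethyl, with a 1.6-fold higher number from compound 1 to compound 4 (0.21 log units; within the scatter), so 2-methyl-4-(trifluoromethyl)-1H-imidazol-1-yl and 3-(trifluoromethyl)-1H-1,2,4-triazol-1-yl cannot be told apart in this read-out. For the compounds shown here, the one new step beyond the scatter involves 2-phenyl-1H-imidazol-1-yl, with a 3.2-fold higher number from compound 2 to compound 4 (0.51 log units; beyond the scatter), so compound 2 now stands apart from two of the other compounds, though compound 1 goes against a clean separation, as its step to compound 2 stays within the scatter.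

No supporting data accompany these compounds to explain any of these differences. From the compounds shown here alone, it remains open whether an imidazolyl ring carrying an amine or a carboxylic acid, or a longer chain in place of the methyl group of 2-methyl-4-(trifluoromethyl)-1H-imidazol-1-yl, would move the number beyond the scatter.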